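The source may report more compounds than this note shows. Statements on the series, on what has been measured and on what is new or still open speak of the compounds shown alone.

Measured compounds in an in vitro assay on BTI-TN-5B1-4 cells for inhibition of Amine oxidase [flavin-containing] B (Homo sapiens), tested at 100 uM; a lower number here means less inhibition, a higher number more inhibition at the concentration tested (going by the name of the read-out):
Compound 1 `COc1ccc(-c2cc(=S)c3ccc(C)cc3o2)cc1` gives 40%.
Compound 2 `Cc1ccc2c(=O)cc(-c3ccc(F)cc3)oc2c1` gives 40%.
Compound 3 `Cc1ccc(-c2cc(=O)c3ccc(C)cc3o2)cc1` gives 40%.

All three values sit within the usual scatter of one another, so no order among compounds 1, 2 and 3 can be read from them. Compound 4 `COc1ccc(-c2cc(=S)c3ccc(F)cc3o2)cc1` has not yet been measured. It arises from compound 1 by a single change, (fluoro in place of methyl on an aromatic carbon). The same kind of change was made between two measured compounds, from compound 3 to compound 2: fluoro in place of methyl on an aromatic carbon. That step gave no change at the digits printed from compound 3 to compound 2 (within the scatter). The two places are not identical: in compound 4 the ring carrying the change is part of a fused or bridged system of two rings, meta to a fused ring and para to a fused ring, whereas in compound 2 the position is para to a large group. How the core of compound 1 differs from that of compound 3 is not broken down here. For compound 4 the expected step is no change at the digits printed from compound 1 to compound 4 (within the scatter), resting on the earlier step of no change at the digits printed from compound 3 to compound 2 (within the scatter) and on compound 1 sitting level with compounds 2 and 3. Compound 4 is therefore estimated at 40%, between 25% and 55%.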

Compound 4, a percentage reported as inhibition, at one concentration (the size of the read-out at that concentration, not a potency): 40%
Compound 4: middle estimate and measured number agree at the digits printed; low and high end bracket the measured number.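

In this assay, fluoro in place of methyl on an aromatic carbon of the core of compound 1 gives no change at the digits printed from compound 1 to compound 4 (within the scatter). Set beside the same swap on a second core, the outcome carries over: the same change on two cores in this assay, no change at the digits printed (within the scatter) from compound 3 to compound 2 and no change at the digits printed (within the scatter) from compound 1 to compound 4, 0 percentage points apart, within the scatter of two such steps This shows only that the swap left the read-out flat on both cores, in two places that are not identical; it does not show that the two groups are equivalent, since a reading at a single concentration is not a potency, and a difference in potency could stay hidden in it, while a step with no visible change says little about how a larger step would carry from core to core.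

Still open, going by these compounds, is whether a different group on that aromatic carbon, such as an amine, a carboxylic acid or a longer chain, would move the read-out on either core. Also open, on these data alone, is whether these compounds would separate from one another at other concentrations.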